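The compounds below may be only part of what the source reports. "The series", "measured", "known", "first", "only" and "open" are said of these compounds alone.

Working notes on the series.

Compound 2 `O=C(/C=C/c1ccc(Cl)cc1)c1ccc(NC(=S)Nc2ccc(Cl)cc2)cc1` gives 100% in a functional assay on the whole organism (Abdomen, strain Swiss) for inhibition, with Mus musculus as the target, with a stated time of 30 min, at a dose of 10 mg/kg by the intraperitoneal route; a lower number here means less inhibition, a higher number more inhibition at the dose given (going by the name of the read-out). Compound 1 `COc1ccc(/C=C/C(=O)c2ccc(NC(=S)Nc3ccc(Cl)cc3)cc2)cc1` differs from compound 2 by methoxy in place of chloro on an aromatic carbon; in this assay compound 1 gives 92%, and the step of a number 8 percentage points lower from compound 2 to compound 1 (within the scatter), so these two numbers are not told apart. Compound 3 `O=C(Nc1ccc(Cl)cc1)Nc1ccc(C(=O)/C=C/c2ccc(Cl)cc2)cc1` is built on a core of a different kind; the difference between the two cores is not broken down here. In this assay compound 3 gives 51%, the lowest of the three numbers, and its gap to compound 1 as well as to compound 2 is beyond the scatter.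

Compound 4 `COc1ccc(/C=C/C(=O)c2ccc(NC(=O)Nc3ccc(Cl)cc3)cc2)cc1` has not yet been measured. It differs from compound 3 by methoxy in place of chloro on an aromatic carbon, the same change that leads from compound 2 to compound 1; the change occurs twice among these compounds, and the two place descriptions agree word for word. Within the data shown here, the single precedent for the change is the step of a number 8 percentage points lower from compound 2 to compound 1 (within the scatter), which lay within the scatter. The expectation for compound 4 therefore rests on that step carried over to compound 3 at 51%, with the caveat that the precedent sits on the other core and is one pair only. The step from compound 3 to compound 4 is expected to be a number 6 percentage points lower from compound 3 to compound 4 (within the scatter). For compound 4 in this assay the estimate is 45%, expected to fall between 25% and 65%.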

Compound 4, a percentage reported as inhibition, in the whole organism at one dose (the size of the read-out at that dose, not a potency): 84.4%
Beside the measured number, compound 4's estimate is 39.4 percentage points below it; the measured number lies above the stated range.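

In this assay, methoxy in place of chloro on an aromatic carbon gives a number 33.4 percentage points higher from compound 3 to compound 4 (beyond the scatter), so the step seen on one core does not carry over unchanged to the other: the same change on two cores in this assay, a number 8 percentage points lower (within the scatter) from compound 2 to compound 1 and a number 33.4 percentage points higher (beyond the scatter) from compound 3 to compound 4, 41.4 percentage points apart, beyond the scatter of two such steps In this series, then, the step for going from 4-chlorophenyl to 4-methoxyphenyl has to be read for each core separately, and a result on the core of compound 1 gives no reliable size for the same change on the core of compound 3. This does not show why the two steps differ, and it rests on two pairs at a single dose, where the read-out is not a potency and compound 2, at 100%, stands at the top of a percentage scale, so the pair on that core may not show the full size of the step.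

From the compounds shown here alone, it remains open whether the dependence on the core extends to other groups at this place, such as fluoro, a dimethylamino group, a carboxylic acid or a longer chain like ethoxy. Also open, going by these compounds, is how the two cores would rank across a range of doses rather than at the one dose given.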